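This account rests on a few compounds, and the source may have more. Where it says the series, first, only, none or still open, it means among the compounds named here.

In a functional assay on MCF7 cells (Homo sapiens) for inhibition, read by MTT assay, with a stated time of 48 h (on this read-out lower numbers stand for stronger inhibition and higher numbers for weaker inhibition), compound 1 `c1ccc(-c2nn(-c3ccccc3)c3nccc(-c4cccs4)c23)cc1` gives 39300 nM and compound 2 `O=C(C=CNc1cc(-c2ccccc2)nn1-c1ccccc1)c1ccc(Br)cc1` gives 21700 nM. Among the measured compounds shown here, these two numbers lie within the usual scatter of each other, so compound 1 stands level with the only other measured compound. Compound 3 `Clc1ccc(-c2ccnc3c2c(-c2ccccc2)nn3-c2ccccc2)cc1` keeps the core of compound 1 but carries 4-chlorophenyl in place of thiophen-2-yl on an aromatic carbon, opposite the ring nitrogen: 4-chlorophenyl in place of thiophen-2-yl on an aromatic carbon. For the measured compounds named here, no measured pair shows what such a swap does, so no change beyond the scatter is expected. The expected step, a 1.3-fold lower number from compound 1 to compound 3 (0.12 log units; within the scatter), is only an estimate. Compound 3 is estimated at 30000 nM, within a range of 10000 nM to 80000 nM.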

Compound 3, half-maximal inhibitory concentration: 61100 nM
For compound 3 the middle estimate is 2.0-fold (0.31 log units) below the measured one, and the stated range covers the measured number.
By their numbers in this assay, from the lowest: compounds 2, 1 and 3 (each within the scatter of the next, the first and the last beyond it).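

On an aromatic carbon opposite the ring nitrogen, putting 4-chlorophenyl in place of thiophen-2-yl gives a 1.6-fold higher number from compound 1 to compound 3 (0.19 log units; within the scatter) in this assay on the shared core. Among the compounds shown here, this is the first reading at this position: a six-membered aromatic ring of carbon only and a five-membered aromatic ring with a sulfur atom give numbers that cannot be told apart. Nothing measured here explains this result. As far as these compounds go, whether an amine, a carboxylic acid or a longer chain at this position would move the number beyond the scatter remains open.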